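A few compounds are considered here, and "the series" means these few. Any claim that something is new, unique, unknown or untested is made for them only; others in the source may bear on it.

Compound 2 `CC(C)[C@@H](N)COc1nc(NC(=N)N)c2ncn(C(C)C)c2n1` stands highest of the two numbers recorded in a functional assay on MCF7 cells (Homo sapiens) for inhibition, read by fluorescence, with a stated time of 72 h; on this read-out higher numbers stand for weaker inhibition and lower numbers for stronger inhibition; its nearest neighbour is compound 1 `CC[C@H](N)COc1nc(NC(=N)N)c2ncn(C(C)C)c2n1`, and in this assay compound 1 gives 16300 nM while compound 2 gives 79400 nM. Going by the values given here, the one measured step, a 4.9-fold higher number from compound 1 to compound 2 (0.69 log units; beyond the scatter), is the only guide, and it concerns the same saturated chain carbon bound to an oxygen on the aromatic ring. Compound 3 `CC(C)n1cnc2c(NC(=N)N)nc(OC[C@H]3CCCN3)nc21` differs from compound 2 at that same place: pyrrolidin-2-yl in place of 1-amino-2-methylpropyl on a saturated chain carbon bound to an oxygen on an aromatic ring. Here the chain is closed into a ring rather than branched further, so the measured step bears on it only loosely, and it points to a modest change in the opposite direction rather than a large one. Compound 3 is therefore expected to show a 2.6-fold lower number from compound 2 to compound 3 (0.42 log units; beyond the scatter), landing near 30000 nM in this assay, within a range of 8000 nM to 120000 nM.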

Compound 3, half-maximal inhibitory concentration: > 100000 nM
Compound 3 gave a limit, no number (the forecaster's own chance of this, stated with the estimate: 15%); at least 3.3-fold (0.52 log units) between middle value and limit.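

In this assay compound 3 gives > 100000 nM, which is a limit of the assay and not a number. Closing the chain into pyrrolidin-2-yl, with the heavy-atom count unchanged, does not bring the read-out back towards that of the 1-aminopropyl compound: the change gives an at least 6.1-fold higher number from compound 1 to compound 3 (0.78 log units; beyond the scatter), whereas an at least 1.2-fold higher number from compound 2 to compound 3 (0.10 log units; that floor lies within the scatter) sets only a floor, so the data do not separate compound 3 from compound 2. This position therefore shows no gain from the ring, and the size of the change stays bounded by the assay's ceiling: the limit of > 100000 nM in this assay, at which 1 of the 3 values shown sits.

The compounds shown leave open how far compound 3 really lies from compound 2. They also leave open whether a piperidin-2-yl ring, or a hydroxyl in place of the amine, would read differently at this place.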